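The source may hold more compounds than are shown below. What is called first, only, known or untested is meant among the compounds shown, and "the series" means these compounds.

Compound 1 `CN(C)c1ccc(C(=O)N2CCC(n3cncc3-c3ccc(OS(=O)(=O)c4cccc5cnccc45)cc3)CC2)cc1` gives the lowest of the two numbers in an assay on HEK293 cells for antagonist activity at P2X purinoceptor 7 (Homo sapiens), read by fluorescence, with a stated time of 2 h (on this read-out lower numbers stand for stronger inhibition and higher numbers for weaker inhibition), at 0.11 nM. For the measured compounds named here, its only measured neighbour, compound 2 `CCN(CC)c1ccc(C(=O)N2CCC(n3cncc3-c3ccc(OS(=O)(=O)c4cccc5cnccc45)cc3)CC2)cc1`, gives 1440 nM. The step of a 13000-fold higher number from compound 1 to compound 2 (4.12 log units; beyond the scatter) goes with a change at the dimethylamino group. Going by the values given here, compound 3 `CN(C)c1ccc(C(=O)N2CCC(n3cncc3-c3ccc(OS(=O)(=O)c4cccc(C#N)c4)cc3)CC2)cc1` differs from compound 1 at another place: 3-cyanophenyl in place of isoquinolin-5-yl on a sulfonyl sulfur, a site that no measured step touches. The measured step from compound 1 to compound 2 therefore does not bear on this change, and its outcome is open. Compound 3 is expected to give 3 nM, within 0.2 nM to 50 nM, an estimated step of a 27-fold higher number from compound 1 to compound 3 (1.44 log units; beyond the scatter).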

Compound 3, half-maximal inhibitory concentration: 32 nM
For compound 3 the middle estimate is 11-fold (1.03 log units) below the measured one; low and high end bracket the measured number.
By their numbers in this assay, from the lowest: compound 1; then compound 3; then compound 2.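

Exchanging isoquinolin-5-yl for 3-cyanophenyl on the sulfonyl sulfur gives a 290-fold higher number from compound 1 to compound 3 (2.46 log units; beyond the scatter). This shows that the group at this site, which the earlier step left untouched, also strongly affects the inhibition measured, and that the two-ring isoquinolin-5-yl goes with the lower number here. Nothing measured here gives a reason for this rise. The compounds shown leave open whether the outcome follows from the nitrile, from the missing second ring or from the ring nitrogen; phenyl or naphthalen-1-yl on the sulfonyl sulfur would help to separate these.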